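Branching the chain beside the amine: compound 3

The source may hold more compounds than are shown below. What is called first, only, known or untested is meant among the compounds shown, and "the series" means these compounds.

Measured so far:
compound 1 `CCCCCCCOc1ccc(CCC(N)(CO)CCC)cc1` in a functional assay on the whole organism (Popliteal lymph node) with Rattus norvegicus as the target (on this read-out lower numbers stand for an effect already at smaller amounts and higher numbers for an effect only at larger amounts of compound), gives 3.1 mg/kg;
compound 2 `CCCCCCCOc1ccc(CC[C@@](N)(CO)CCC)cc1` in this assay gives 0.63 mg/kg.

Compound 2 has the lowest of the two numbers; its nearest neighbour is compound 1, and the change gave a 4.9-fold lower number from compound 1 to compound 2 (0.69 log units; beyond the scatter). That step rests only on one stereocentre drawn with or without configuration (the fact that one of compounds 1 and 2 is drawn with a defined configuration and the other without, at the place where they differ).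

Compound 3 `CCCCCCCOc1ccc(CCC(N)(CO)C(C)C)cc1` has the same atoms as compound 2, joined differently: a group of 7 heavy atoms (5 carbon, 1 nitrogen, 1 oxygen; no ring) in place of a group of 7 heavy atoms (5 carbon, 1 nitrogen, 1 oxygen; no ring), on a saturated chain carbon, two bonds along the chain from an aromatic carbon. Among the compounds with values here, no measured step matches this change, and compound 3 carries no defined stereocentre, like compound 1. A step of about a 4.8-fold higher number from compound 2 to compound 3 (0.68 log units; beyond the scatter) is therefore expected. For compound 3 in this assay the estimate is 3 mg/kg, within 1 mg/kg to 10 mg/kg.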

Compound 3, dose for 50% inhibition: 2.7 mg/kg
Compound 3: middle estimate off by 1.1-fold (0.05 log units), on the high side; low and high end bracket the measured number.
By their numbers in this assay, from the lowest: compound 2; then compounds 3 and 1 (each within the scatter of the next).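

Isopropyl in place of propyl, with neither compound drawn with a configuration, gives in this assay a 1.1-fold lower number from compound 1 to compound 3 (0.06 log units; within the scatter) and so at this position the branched and the straight chain cannot be told apart. The step of a 4.3-fold higher number from compound 2 to compound 3 (0.63 log units; beyond the scatter) cannot be read as a single change: the branch and the drawn configuration differ together. As far as these compounds go, it remains open whether a single defined configuration of compound 3 would give a lower number, as compound 2 does against compound 1. Also open, from the compounds shown here alone, is how a longer chain such as butyl, or a cyclopropyl group, would read in this place.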